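Compound 3 at the Limit: A 4-Hydroxyphenyl Swap

A few compounds are considered here, and "the series" means these few. Any claim that something is new, unique, unknown or untested is made for them only; others in the source may bear on it.

Compound 1 `COc1ccc(OC)c(Nc2nc(/C=C/c3ccccc3OC(C)=O)nc3ccccc23)c1`: > 25000 nM (a limit)
Compound 2 `CC(=O)Oc1ccc(/C=C/c2nc3ccccc3c(=O)[nH]2)c(OC(C)=O)c1`: > 25000 nM (a limit)
Compound 3 `COc1ccccc1/C=C/c1nc(Nc2ccccc2Cl)c2ccccc2n1`: > 25000 nM (a limit)

In a functional assay on HCT-116 cells (Homo sapiens) for antiproliferative activity, with a stated time of 72 h (on this read-out higher numbers stand for weaker inhibition and lower numbers for stronger inhibition), compound 3 gives > 25000 nM, which is a limit and not a number. It has no measured neighbour to set it apart, and the evidence shows (the limit of > 25000 nM in this assay, at which 3 of the 3 values shown sit). Compound 4 `COc1ccccc1/C=C/c1nc(Nc2ccc(O)cc2)c2ccccc2n1` carries 4-hydroxyphenyl in place of 2-chlorophenyl on a nitrogen on an aromatic ring. For the measured compounds named here, no step between measured compounds is available to size this change. A modest move towards stronger inhibition is expected, though compound 4 may well stay at the limit. The expected size is an at least 2.7-fold lower number from compound 3 to compound 4 (0.44 log units; beyond the scatter). For compound 4 the estimated value is 9000 nM, with an expected range from 2000 nM to 25000 nM.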

Compound 4, half-maximal inhibitory concentration: > 25000 nM
Compound 4: a limit, no number; the forecaster's own chance of this, stated with the estimate: 40%; middle value at least 2.7-fold (0.44 log units) from the limit.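

Compound 3 and compound 4 both stand as limits and not as numbers, so the swap from 2-chlorophenyl to 4-hydroxyphenyl gives no readable step: the limit of > 25000 nM in this assay, at which 4 of the 4 values shown sit. The compounds shown leave open which change, if any, would give a measurable value.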